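The source may report more compounds than this note shows. Statements on the series, on what has been measured and on what is new or still open speak of the compounds shown alone.

Measured in an ADME assay (liver) for metabolic stability, with Liver microsome (Homo sapiens) as the target, using microsomes and NADPH, with a stated time of 30 min, tested at 1 uM; on this read-out lower numbers stand for slow clearance and higher numbers for fast clearance:
Compound 1 `Nc1ccc(S(=O)(=O)N2CCN(c3ncc(C(O)(C(F)(F)F)C(F)(F)F)cc3C#CCO)CC2)cn1`: < 14 mL.min-1.g-1 (a limit, not a number)
Compound 2 `CC(C)(O)C#Cc1cc(C(O)(C(F)(F)F)C(F)(F)F)cnc1N1CCN(S(=O)(=O)c2ccc(N)nc2)CC1`: < 14 mL.min-1.g-1 (a limit, not a number)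
Compound 3 `CS(=O)(=O)Nc1cccc(-c2cc(C(O)(C(F)(F)F)C(F)(F)F)cnc2N2CCN(S(=O)(=O)c3ccc(N)nc3)CC2)c1`: 40 mL.min-1.g-1

Going by the values given here, compound 3 gives the only true number of the three, 40 mL.min-1.g-1. Compound 1 and compound 2 both stop at a limit: the limit of < 14 mL.min-1.g-1 in this assay, at which 2 of the 3 values shown sit.

Two measured steps lead to compound 3, each placing 3-(methanesulfonamido)phenyl where a triple-bonded group stood: an at least 2.8-fold higher number from compound 1 to compound 3 (0.45 log units; beyond the scatter) and an at least 2.8-fold higher number from compound 2 to compound 3 (0.45 log units; beyond the scatter). Compound 4 `Cc1ccc(-c2cc(C(O)(C(F)(F)F)C(F)(F)F)cnc2N2CCN(S(=O)(=O)c3ccc(N)nc3)CC2)cn1` changes that same group again: 6-methylpyridin-3-yl in place of 3-(methanesulfonamido)phenyl on an aromatic carbon. Here one aromatic ring replaces another, a swap that no measured step covers, so those two steps give only a loose guide. The closest anchor is compound 3 at 40 mL.min-1.g-1, and no step beyond the usual scatter is expected in this assay. The expected step is a 1.3-fold lower number from compound 3 to compound 4 (0.12 log units; within the scatter). For compound 4 the estimate is 30 mL.min-1.g-1, with an expected range of 14 mL.min-1.g-1 to 70 mL.min-1.g-1.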

Compound 4, intrinsic clearance in microsomes: 43 mL.min-1.g-1
Estimate against measurement, compound 4: 1.4-fold (0.16 log units) below; the range from low to high includes it.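

In this assay one aromatic ring now replaces another at this position, with a 1.1-fold higher number from compound 3 to compound 4 (0.03 log units; within the scatter) as the result, so the number reached by compound 3 does not depend on its methanesulfonamido group. The second aromatic ring repeats the gap to the triple-bonded groups, with an at least 3.0-fold higher number from compound 2 to compound 4 (0.48 log units; beyond the scatter) and an at least 3.0-fold higher number from compound 1 to compound 4 (0.48 log units; beyond the scatter) as well. On these data alone, those two steps start from a limit, not a number, so their true size stays unknown: the limit of < 14 mL.min-1.g-1 in this assay, at which 2 of the 4 values shown sit.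

As far as these compounds go, it remains open whether the higher numbers follow from having an aromatic ring at this position or simply from losing the triple-bonded group. A saturated ring such as morpholine, or a short alkyl chain, at this position would help to separate these two readings.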